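A few compounds are considered here, and "the series" means these few. Any claim that something is new, unique, unknown or untested is made for them only; others in the source may bear on it.

The measured compounds:
Compound 1, `COc1ccccc1C(=O)/C=C/c1ccc2c(c1)B(O)OC2`, in an ADME assay on L929 cells (Mus musculus) for cytotoxicity, read by resazurin assay, with a stated time of 72 h (a higher number here means a weaker inhibitor, a lower number a stronger inhibitor), gives 6.35 ug/mL.
Compound 2, `O=C(/C=C/c1ccc2c(c1)B(O)OC2)c1cccc(F)c1`, in this assay gives only a limit, > 10 ug/mL.

Compound 2 therefore stands at the limit of > 10 ug/mL in this assay, at which 1 of the 2 values shown sits, and no number is known for it. Among the compounds with values here, compound 1 yields a number where compound 2 yields none; more than that the two values do not show, and no step between them has been worked out.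

Compound 3, `O=C(/C=C/c1ccc2c(c1)B(O)OC2)c1ccc(Cl)cc1`, has not yet been measured in this assay. It differs from compound 2 in one place: 4-chlorophenyl in place of 3-fluorophenyl on a carbonyl carbon. The shared core and the chain that carries the carbonyl are untouched. Within the data shown here, no step between measured compounds bears on this exchange, so the expectation rests on compound 2 alone, whose value is only a limit. The account expects the step from compound 2 to compound 3 to be a number no higher from compound 2 to compound 3 (the limit leaves the size open), that is, nothing beyond the usual scatter in either direction. Compound 3 is expected to come out near 10 ug/mL, within a range from 4 ug/mL to 25 ug/mL, with a real chance that this assay again reports only a limit for it.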

Compound 3, half-maximal inhibitory concentration: > 10 ug/mL
Compound 3: no number, only a limit (the forecaster's own chance of this, stated with the estimate: 50%); the middle value sits exactly at the limit.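

In this assay compound 3, like compound 2, gives only a limit and not a number, so no step can be read between compound 2 and compound 3: the limit of > 10 ug/mL in this assay, at which 2 of the 3 values shown sit.

The compounds shown leave open whether 4-chlorophenyl in place of 3-fluorophenyl on a carbonyl carbon makes any difference in this assay beyond these limits.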